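Para-substituent swap on a guanidine-urea series: chloro to trifluoromethoxy

The compounds below may be only part of what the source reports. "The series", "measured", "known", "first", "only" and "open" are said of these compounds alone.

Measured so far:
compound 1, `COc1ccc(C(C)NC(=O)/N=C(\N)NCCCc2sc(N)nc2C)cc1`, 37.2 nM
compound 2, `Cc1nc(N)sc1CCCN/C(N)=N/C(=O)NC(C)c1ccc(Br)cc1`, 30.2 nM
compound 3, `Cc1nc(N)sc1CCCN/C(N)=N/C(=O)NC(C)c1ccc(Cl)cc1`, 46.8 nM

All three were tested in an assay on membranes from Sf9 cells for displacement of a labelled ligand from histamine H2 receptor (Homo sapiens), read by scintillation counting, with a stated time of 60 min; a higher number here means a weaker inhibitor, a lower number a stronger inhibitor. Compound 3 has the highest number of the three, yet its distance to compound 1, a 1.3-fold higher number from compound 1 to compound 3 (0.10 log units; within the scatter), and to compound 2, a 1.5-fold higher number from compound 2 to compound 3 (0.19 log units; within the scatter), both stay within the scatter, as does a 1.2-fold lower number from compound 1 to compound 2 (0.09 log units; within the scatter); the three aromatic substituents tried so far therefore look interchangeable. Compound 4, `Cc1nc(N)sc1CCCN/C(N)=N/C(=O)NC(C)c1ccc(OC(F)(F)F)cc1`, carries the change (trifluoromethoxy in place of chloro on an aromatic carbon). The bearing steps are those three, each small. Compound 4 is therefore expected to give a number close to compound 3, the step of a 1.2-fold lower number from compound 3 to compound 4 (0.07 log units; within the scatter) lying within the scatter. The estimate for compound 4 is 40 nM, with a range from 15 nM to 110 nM.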

Compound 4, inhibition constant: 126 nM
Compound 4: the middle estimate sits 3.2-fold (0.50 log units) below what was measured, and the stated range ends below it.
By their numbers in this assay, from the lowest: compounds 2, 1 and 3 (each within the scatter of the next); then compound 4.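

This position does not accept every group equally: trifluoromethoxy gives a 2.7-fold higher number from compound 3 to compound 4 (0.43 log units; beyond the scatter) and a 4.2-fold higher number from compound 2 to compound 4 (0.62 log units; beyond the scatter) and also a 3.4-fold higher number from compound 1 to compound 4 (0.53 log units; beyond the scatter) at the same position. Chloro, bromo and methoxy stayed within the scatter of one another, so this is the first change here to go beyond it. The last step is the closest comparison, since both groups attach through oxygen and only methyl becomes trifluoromethyl.

From the compounds shown here alone, whether an amine or a carboxylic acid on this carbon would match compounds 1, 2 and 3 or compound 4 remains open. The compounds shown come with no measurement that explains the weaker binding of compound 4.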